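The source may hold more compounds than are shown below. What is called first, only, known or untested is meant among the compounds shown, and "the series" means these compounds.

Measured in a functional assay on MGC-803 cells (Homo sapiens) for inhibition, read by sulforhodamine B assay; on this read-out higher numbers stand for weaker inhibition and lower numbers for stronger inhibition:

Compound 1 `O=C1C(Nc2ccccc2)=CC(=O)c2c1nc1n2[C@H]2OC[C@@H](O)[C@H]2OC1`: 1830 nM
Compound 2 `Cc1ccc(NC2=CC(=O)c3c(nc4n3[C@H]3OC[C@@H](O)[C@H]3OC4)C2=O)cc1`: 1550 nM
Compound 3 `O=C1C(N2CCCCC2)=CC(=O)c2c1nc1n2[C@H]2OC[C@@H](O)[C@H]2OC1`: > 4000 nM, a limit and not a number

Compound 3 stands at the limit of > 4000 nM in this assay, at which 1 of the 3 values shown sits, so it has no number to start from. The step under consideration leads to compound 4 `CCCN(CCC)C1=CC(=O)c2c(nc3n2[C@H]2OC[C@@H](O)[C@H]2OC3)C1=O`, which has not yet been measured. The change is dipropylamino in place of piperidin-1-yl on a double-bonded ring carbon.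

Among the measured compounds shown here, no measured step makes this exact change. The nearest evidence is an at least 2.1-fold higher number from compound 1 to compound 3 (0.33 log units; beyond the scatter) and an at least 2.5-fold higher number from compound 2 to compound 3 (0.41 log units; beyond the scatter), both of which put piperidin-1-yl in place of an aromatic amino group. By contrast, the methyl change gave a 1.2-fold lower number from compound 1 to compound 2 (0.07 log units; within the scatter), so compound 1 and compound 2 form one level within the scatter. Like compound 3, compound 4 lacks the anilino or (4-methylphenyl)amino group, so it is expected to stay on the weak side of compound 1, with its 1830 nM. In this assay, no step beyond the scatter is expected for the exchange of piperidin-1-yl for dipropylamino, and a report of only a limit is quite likely. The step expected from the estimate is a step that the limit leaves unreadable from compound 3 to compound 4. For compound 4 the estimated value is 4500 nM, with an expected range from 2200 nM to 9000 nM.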

Compound 4, half-maximal inhibitory concentration: > 16000 nM
Compound 4: a limit, no number; the forecaster's own chance of this, stated with the estimate: 60%; middle value at least 3.5-fold (0.55 log units) from the limit.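

Compound 4 is reported in this assay only as a limit and not as a number: the limit of > 16000 nM in this assay, at which 1 of the 4 values shown sits.

Its limit still shows that the loss seen on leaving the aromatic amino groups does not depend on the ring of piperidin-1-yl: dipropylamino, which has no ring, gives an at least 10-fold higher number from compound 2 to compound 4 (1.01 log units; beyond the scatter) in place of (4-methylphenyl)amino and an at least 8.7-fold higher number from compound 1 to compound 4 (0.94 log units; beyond the scatter) in place of anilino. Compound 3 also stands only as a limit, so the step between the two dialkylamino-type compounds cannot be read and neither group can be placed ahead of the other: the limit of > 4000 nM in this assay, at which 1 of the 4 values shown sits.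

The compounds shown leave open how far above their limits compound 3 and compound 4 truly lie, and whether a shorter chain such as dimethylamino or a ring holding a second hetero atom such as morpholin-4-yl would behave the same way at this carbon. They also leave open whether benzylamino, which keeps an aromatic ring in the group, would return to the level of compound 1 and compound 2, or whether anilino groups carrying chloro or methoxy would move that level.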